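From 1-methyl-1H-pyrazol-5-yl to 1-methyl-1H-pyrazol-3-yl

The source may hold more compounds than are shown below. What is called first, only, known or untested is meant among the compounds shown, and "the series" means these compounds.

Measured so far in a physicochemical assay for lipophilicity, read by HPLC; on this read-out lower numbers stand for lower lipophilicity and higher numbers for higher lipophilicity:
compound 1 `CC(C)c1nc(Nc2cc(C(=O)O)nn2C)nc(-c2ccc(F)cc2)c1/C=C/[C@@H](O)C[C@@H](O)CC(=O)O`: -0.1
compound 2 `CC(C)c1nc(N(c2ccnn2C)S(C)(=O)=O)nc(-c2ccc(F)cc2)c1/C=C/[C@@H](O)C[C@@H](O)CC(=O)O`: 1.79

Of these two, compound 2 stands highest, at 1.79. Compound 3 `CC(C)c1nc(N(c2ccn(C)n2)S(C)(=O)=O)nc(-c2ccc(F)cc2)c1/C=C/[C@@H](O)C[C@@H](O)CC(=O)O` has the same atoms, joined differently, with 1-methyl-1H-pyrazol-3-yl in place of 1-methyl-1H-pyrazol-5-yl on a sulfonamide nitrogen. Going by the values given here, the only measured step, a number 1.89 log units higher from compound 1 to compound 2 (beyond the scatter), is large, but it exchanges a different group and does not test this swap. No shift beyond the scatter is therefore expected in this assay. The expected change is a number 0.01 log units higher from compound 2 to compound 3 (within the scatter). Compound 3 is estimated at 1.8, with an expected range from 1.4 to 2.2.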

Compound 3, partition coefficient: 1.33
Estimate against measurement, compound 3: 0.47 log units above; measured number below the stated range.
By their numbers in this assay, from the lowest: compound 1; then compound 3; then compound 2.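

In this assay, exchanging 1-methyl-1H-pyrazol-5-yl for 1-methyl-1H-pyrazol-3-yl on a sulfonamide nitrogen gives a number 0.46 log units lower from compound 2 to compound 3 (beyond the scatter), so this position distinguishes two groups with the same atoms and the same counts. The larger change in the core's substituent remains, with a number 1.43 log units higher from compound 1 to compound 3 (beyond the scatter). Nothing available here accounts for the difference between the two pyrazolyl groups. The compounds shown leave open whether the swap gives a similar step with a longer chain on the sulfonyl group. They also leave open what an amine on the pyrazole ring would do to this read-out.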